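The source may hold more compounds than are shown below. What is called first, only, known or untested is meant among the compounds shown, and "the series" means these compounds.

Compound 1 `CCCc1cccnc1Nc1cccc(C)n1`: 394 nM
Compound 2 `CCOc1cc(C#N)cnc1Nc1cccc(C)n1`: 46 nM

In an assay on Ltk cells with metabotropic glutamate receptor 5 (Homo sapiens) as the target, read by fluorescence and calcium flux (a higher number here means a weaker inhibitor, a lower number a stronger inhibitor), compound 1 gives 394 nM, while compound 2 gives 46 nM, the lower of the two numbers shown; its gap to compound 1 lies beyond the usual scatter. Compound 3 `CCOc1cc(-c2cnccc2C)cnc1Nc1cccc(C)n1` differs from compound 2 in one place: 4-methylpyridin-3-yl in place of cyano on an aromatic carbon. For the measured compounds named here, no measured pair shows such a change, so there is nothing to set its size by. The expected step is a 1.7-fold higher number from compound 2 to compound 3 (0.24 log units; within the scatter), at most a small weakening, possibly none beyond the scatter. Compound 3 is therefore estimated at 80 nM, within a range from 20 nM to 400 nM.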

Compound 3, half-maximal inhibitory concentration: 45 nM
Estimate against measurement, compound 3: 1.8-fold (0.25 log units) above, within the range that was stated.
By their numbers in this assay, from the lowest: compounds 3 and 2 (each within the scatter of the next); then compound 1.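

In this assay the exchange of cyano for 4-methylpyridin-3-yl gives a 1.0-fold lower number from compound 2 to compound 3 (0.01 log units; within the scatter) and so stays within the scatter. For the compounds shown here, the position, on an aromatic carbon two atoms from the ring nitrogen, therefore accepts a six-membered aromatic ring of 7 heavy atoms in place of a group of 2 heavy atoms, which the earlier compounds could not show. Nothing available accounts for this result. Still open, going by these compounds, is how an amine, a carboxylic acid or a morpholine ring on this carbon would compare. Also open, on these data alone, is how a plain pyridin-3-yl would compare.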